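Swapping the aryl group on a hydrazone urea series

The source may hold more compounds than are shown below. What is called first, only, known or untested is meant among the compounds shown, and "the series" means these compounds.

Compound 1 `COc1ccc(OC)c(/C=N/NC(=O)Nc2ccc(Oc3ccnc(-c4nncn4CCN(C)C)c3)c(F)c2)c1` shares its core with compound 2 `CN(C)CCn1cnnc1-c1cc(Oc2ccc(NC(=O)N/N=C/c3cccc(Br)c3)cc2F)ccn1` and compound 3 `CN(C)CCn1cnnc1-c1cc(Oc2ccc(NC(=O)N/N=C/c3ccc(O)c(F)c3)cc2F)ccn1`; the three differ only in the aromatic group attached to the carbon with a double bond to nitrogen. In an ADME assay on WI-38 cells (Homo sapiens) for cytotoxicity, read by MTT assay, with a stated time of 72 h (on this read-out lower numbers stand for stronger inhibition and higher numbers for weaker inhibition), compound 2 gives 4230 nM, while compound 1 gives "not determined" (no result reported) and compound 3 gives "not determined" (no result reported), so compound 1 stands without a number of its own. Compound 4 `CN(C)CCn1cnnc1-c1cc(Oc2ccc(NC(=O)N/N=C/c3ccc(Cl)cc3Cl)cc2F)ccn1` is reached from compound 1 by the change (2,4-dichlorophenyl in place of 2,5-dimethoxyphenyl on a carbon with a double bond to nitrogen). For the measured compounds named here, with no measured step in this assay to draw on, no shift beyond the usual scatter is expected in either direction. Compound 4 is therefore estimated near 4000 nM in this assay, with a range from 1500 nM to 12000 nM.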

Compound 4, half-maximal inhibitory concentration: 4760 nM
For compound 4 the middle estimate is 1.2-fold (0.08 log units) below the measured one; low and high end bracket the measured number.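

For the compounds shown here, this gives the first measured step at this position: in this assay, putting 2,4-dichlorophenyl in place of 3-bromophenyl gives a 1.1-fold higher number from compound 2 to compound 4 (0.05 log units; within the scatter). These two aryl groups therefore cannot be told apart in this read-out, while the change from 2,5-dimethoxyphenyl in compound 1 cannot be read, since compound 1 has no number. Nothing shown explains the result.

Going by these compounds alone, only two halogen-bearing aryl groups have numbers here. On these data alone, whether an aryl group carrying an amine or a carboxylic acid would give a number beyond the scatter remains open.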